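The source may report more compounds than this note shows. Statements on the series, on what has been measured and on what is new or still open speak of the compounds shown alone.

Compound 3 `CCN1CCN(C(=O)/C=C/C=C/[C@H](O)Cc2ccc(OC)c(OC)c2)CC1` gives 11500 nM in a functional assay on MCF7 cells (Homo sapiens) for antiproliferative activity, read by sulforhodamine B assay, with a stated time of 48 h (on this read-out higher numbers stand for weaker inhibition and lower numbers for stronger inhibition), the lowest number of the three shown; it stands nearest compound 1 `CCNC(=O)/C=C/C=C/[C@H](O)Cc1ccc(OC)c(OC)c1` at 12900 nM and furthest from compound 2 `COc1ccc(C[C@@H](O)/C=C/C=C/C(=O)N2CCN(C)CC2)cc1OC` at 17100 nM, both within the scatter. Every step measured so far alters the group on the carbonyl carbon or a substituent on its ring: a 1.3-fold higher number from compound 1 to compound 2 (0.12 log units; within the scatter), a 1.1-fold lower number from compound 1 to compound 3 (0.05 log units; within the scatter) and a 1.5-fold lower number from compound 2 to compound 3 (0.17 log units; within the scatter), none beyond the scatter. Compound 4 `COc1ccc(C[C@@H](O)/C=C/C=C/C(=O)N2CCCC2)cc1OC` carries pyrrolidin-1-yl in place of 4-ethylpiperazin-1-yl on a carbonyl carbon. With a 1.1-fold lower number from compound 1 to compound 3 (0.05 log units; within the scatter) and a 1.5-fold lower number from compound 2 to compound 3 (0.17 log units; within the scatter) both inside the scatter, the step of a 1.1-fold higher number from compound 3 to compound 4 (0.05 log units; within the scatter) is expected to be small, with no clear direction. Compound 4 is therefore estimated at 13000 nM, ranging from 7000 nM to 25000 nM.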

Compound 4, half-maximal inhibitory concentration: 26200 nM
The estimate for compound 4 lay 2.0-fold (0.30 log units) below the measured number, and the stated range ends below it.
By their numbers in this assay, from the lowest: compounds 3, 1, 2 and 4 (each within the scatter of the next, the first and the last beyond it).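

In this assay, going by these compounds alone, the group on the carbonyl carbon moves the number beyond the scatter for the first time: pyrrolidin-1-yl gives a modest rise against 4-ethylpiperazin-1-yl (a 2.3-fold higher number from compound 3 to compound 4 (0.36 log units; beyond the scatter)) and against ethylamino (a 2.0-fold higher number from compound 1 to compound 4 (0.31 log units; beyond the scatter)). Against 4-methylpiperazin-1-yl the step (a 1.5-fold higher number from compound 2 to compound 4 (0.19 log units; within the scatter)) stays within the scatter, so the rise does not hold against every partner. Nothing available here accounts for this shift.

The compounds shown leave open where a piperidin-1-yl or morpholin-4-yl group on this carbonyl carbon would fall. They also leave open how a longer chain on the amide nitrogen would compare with ethylamino.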